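Acylated dithiol series: from free acid to chloroanilide

A few compounds are considered here, and "the series" means these few. Any claim that something is new, unique, unknown or untested is made for them only; others in the source may bear on it.

In a functional assay on HO8910 cells (Homo sapiens) for inhibition, read by MTT assay, with a stated time of 24 h, tested at 1 ug/mL (a higher number here means more inhibition of growth at the concentration tested, a lower number less inhibition of growth), compound 1 (`CC(=O)SCCC(CCCCC(=O)O)SC(C)=O`) is reported as "not active" (no number reported), so it stands without a single number to serve as a baseline. Compound 4 (`CC(=O)SCCC(CCCCC(=O)Nc1cccc(Cl)c1)SC(C)=O`) keeps the core of compound 1 and carries (3-chlorophenyl)amino in place of hydroxy on a carbonyl carbon.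

The nearest comparators also carry an aromatic ring on an amide, but they have free thiols where compound 4 keeps the acetylated sulfur groups of compound 1. Compound 2 (`O=C(CCCCC(S)CCS)Nc1ccc(F)cc1`) gives 12.2%. Compound 3 (`O=C(CCCCC(S)CCS)Nc1ccc([N+](=O)[O-])c(C(F)(F)F)c1`) gives 1.17%.

For the measured compounds named here, no measured step isolates this change. In this assay a small rise in growth inhibition is expected on going to compound 4, possibly none beyond the scatter. This modest expectation rests on compound 2 at 12.2% and compound 3 at 1.17%. A report of no activity would not be surprising. For compound 4 the estimated inhibition is 8%, with an expected range of 0% to 22%.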

Compound 4, percent growth inhibition at one concentration: "not active" (no number reported)
For compound 4 the study gives words and no number; no gap can be computed for the estimate.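

In this assay compound 1 gives "not active" (no number reported) and compound 4 gives "not active" (no number reported) so no step can be read between them. The compounds shown leave open whether (3-chlorophenyl)amino in place of hydroxy alters growth inhibition at all. No supporting evidence bears on this result.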